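Carbamate in place of an ether side chain on PANC-1 inhibition

The compounds below may be only part of what the source reports. "The series", "measured", "known", "first", "only" and "open" are said of these compounds alone.

Measured compounds:
compound 1 `CCOc1cc(=O)n(CCCO)c2c1CC(C/C=C(\C)CCC=C(C)C)C(C)(C)C2`, 0.8%
compound 2 `COc1ccc(OCCCOc2cc(=O)n(CCCO)c3c2CC(C/C=C(\C)CCC=C(C)C)C(C)(C)C3)cc1`, 0%

In a functional assay on PANC-1 cells (Homo sapiens) for inhibition, read by MTT assay, with a stated time of 24 h, tested at 10 uM (a lower number here means less inhibition, a higher number more inhibition at the concentration tested (going by the name of the read-out)), compound 1 gives 0.8% and compound 2 gives 0%, the two sitting together within the scatter of each other, so neither can be called the weaker. Within the data shown here, the one measured step, a number 0.8 percentage points lower from compound 1 to compound 2 (within the scatter), concerns an extension of the side chain and changes nothing beyond the scatter.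

Compound 3 `CC(C)=CCC/C(C)=C/CC1Cc2c(OC(=O)Nc3cccc(F)c3)cc(=O)n(CCCO)c2CC1(C)C` differs from compound 2 as follows: (3-fluorophenyl)carbamoyl in place of 3-(4-methoxyphenoxy)propyl on an oxygen on an aromatic ring. Among the measured compounds shown here, no measured step touches this kind of exchange, so the expectation rests only on the fact that both compounds measured so far, compound 1 and compound 2, sit near the bottom of the read-out. Compound 3 is therefore expected to show a number 5 percentage points higher from compound 2 to compound 3 (within the scatter), a step not beyond the scatter. The value of compound 3 in this assay is estimated at 5%, with a range from 0% to 20%.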

Compound 3, a percentage reported as inhibition, at one concentration (the size of the read-out at that concentration, not a potency): 0%
For compound 3 the middle estimate is 5 percentage points above the measured one; the measured number falls inside the stated range.
By their numbers in this assay, from the lowest: compounds 2, 3 and 1 (each within the scatter of the next).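

In this assay, (3-fluorophenyl)carbamoyl on the oxygen on an aromatic ring gives no change at the digits printed from compound 2 to compound 3 (within the scatter) in place of 3-(4-methoxyphenoxy)propyl, and a number 0.8 percentage points lower from compound 1 to compound 3 (within the scatter) in place of ethyl. The carbamate thus differs in kind from both ether side chains, bringing one hydrogen-bond donor to this place, yet all three compounds remain within the scatter of one another, so this exchange gives no separation in the read-out. Nothing available accounts for this outcome or links it to any property of the groups.

As far as these compounds go, all three values lie close together near the bottom of the read-out, so it remains open whether any group at this oxygen can produce clear inhibition of PANC-1 cells. A side chain ending in an amine or a carboxylic acid, or a carbamate carrying a simple alkyl group in place of the 3-fluorophenyl ring, would be a further test of this place.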